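A Methyl Group and Cytotoxicity in Breast Cancer Cells

The source may report more compounds than this note shows. Statements on the series, on what has been measured and on what is new or still open speak of the compounds shown alone.

In a functional assay on MCF7 cells (Homo sapiens) for cytotoxicity, read by MTT assay, with a stated time of 72 h (a higher number here means a weaker inhibitor, a lower number a stronger inhibitor), compound 1, `O=C1N/C(=N/c2csc(-c3ccc(Cl)cc3)c2)S/C1=C\c1ccccc1`, gives only a limit, > 50000 nM.
In this assay compound 2, `Cc1ccc(/C=C2\S/C(=N\c3csc(-c4ccc(Cl)cc4)c3)NC2=O)cc1`, gives 900 nM.
In this assay compound 3, `O=C1CS/C(=N\c2csc(-c3ccc(Cl)cc3)c2)N1c1ccccc1`, gives only a limit, > 50000 nM.

Compounds 1 and 2 share a core; the difference between that core and the core of compound 3 is not broken down here. Compound 2 differs from compound 1 by a single change, (methyl in place of hydrogen on an aromatic carbon). That change made a large step: an at least 55-fold lower number from compound 1 to compound 2 (1.74 log units; beyond the scatter). Because compound 1 sits at the limit of > 50000 nM in this assay, at which 2 of the 3 values shown sit, only the lower bound of that step is known, and the true step could be larger.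

Compound 4, `Cc1ccc(N2C(=O)CS/C2=N\c2csc(-c3ccc(Cl)cc3)c2)cc1`, is not yet measured. It differs from compound 3 by the same change, (methyl in place of hydrogen on an aromatic carbon), at a place described in the same words as for the pair of compounds 1 and 2. Compound 3, like compound 1, sits at the limit of > 50000 nM in this assay, at which 2 of the 3 values shown sit, so the same change starts from the same point, though on a different core.

Given that the change from compound 1 to compound 2 gave an at least 55-fold lower number from compound 1 to compound 2 (1.74 log units; beyond the scatter), compound 4 is expected to show a step of an at least 5.0-fold lower number from compound 3 to compound 4 (0.69 log units; beyond the scatter). Compound 4 is estimated at about 10000 nM, with a likely range from 1500 nM to 50000 nM.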

Compound 4, half-maximal inhibitory concentration: > 50000 nM
Compound 4 was reported as a limit; the forecaster's own chance of this, stated with the estimate: 40%; middle value at least 5.0-fold (0.69 log units) away from the limit.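

No step can be read from compound 3 to compound 4, because the two results are both limits rather than numbers, and they are the same limit: the limit of > 50000 nM in this assay, at which 3 of the 4 values shown sit.

The compounds shown leave open whether going from phenyl to 4-methylphenyl changes cytotoxicity at all on the core of compound 3, and how far compound 3 and compound 4 each lie beyond that limit.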